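Hydroxycyclohexyl in Place of Methoxycyclohexyl: Expected Permeability

This account rests on a few compounds, and the source may have more. Where it says the series, first, only, none or still open, it means among the compounds named here.

Compound 1 `COc1ccc(-c2c(-c3ccc(OC)cc3)n(Cc3ccccc3)c3ncn([C@H]4CC[C@H](OC)CC4)c(=N)c23)cc1`: > 1000 10^-6 cm/s
Compound 2 `COc1ccc(Cn2c(-c3ccccc3)c(-c3ccccc3)c3c(=N)n(CCCO)cnc32)cc1`: > 1000 10^-6 cm/s

In an ADME assay for permeability, using PAMPA, with a stated time of 30 min, at pH 7.4 (on this read-out lower numbers stand for lower permeability and higher numbers for higher permeability), compound 1 gives > 1000 10^-6 cm/s, which is a limit of the assay rather than a number. Compound 2 gives > 1000 10^-6 cm/s, likewise a limit. Among the measured compounds shown here, both values sit at the limit of > 1000 10^-6 cm/s in this assay, at which 2 of the 2 values shown sit, so compound 1 stands at the top of what this assay reports, and no step between measured compounds is available. Compound 3 `COc1ccc(-c2c(-c3ccc(OC)cc3)n(Cc3ccccc3)c3ncn([C@@H]4CCCC[C@H]4O)c(=N)c23)cc1` differs from compound 1 by 2-hydroxycyclohexyl in place of 4-methoxycyclohexyl on an aromatic nitrogen: in words, 2-hydroxycyclohexyl in place of 4-methoxycyclohexyl on an aromatic nitrogen. Without a measured step as guide, the expected change from compound 1 to compound 3 is an at least 1.2-fold lower number from compound 1 to compound 3 (0.09 log units; that floor lies within the scatter), a modest drop that may stay within the scatter. Compound 3 is estimated at 800 10^-6 cm/s, between 300 10^-6 cm/s and 1500 10^-6 cm/s, with a fair chance of again reaching only the limit.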

Compound 3, apparent permeability: > 1000 10^-6 cm/s
Compound 3: only a limit was reported (the forecaster's own chance of this, stated with the estimate: 50%); at least 1.2-fold (0.09 log units) between middle value and limit.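

In this assay compound 3 gives > 1000 10^-6 cm/s, which is a limit and not a number. Among the compounds shown here, compound 1 also stands at a limit, so no step between compound 1 and compound 3 can be read. Going by these compounds, whether 2-hydroxycyclohexyl in place of 4-methoxycyclohexyl changes the read-out at all remains open.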